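The source may report more compounds than this note shows. Statements on the series, on what has been measured and on what is new or still open speak of the compounds shown alone.

Of the compounds shown here, three built on one shared core have been measured in a functional assay on T47D cells (Homo sapiens) for activation; a higher number here means that more compound is needed for the effect, a lower number that less compound is needed. Compound 1, `CCNc1ccc2c(c1)OC(N)=C(C#N)C2c1cccc([N+](=O)[O-])c1`, gives 110000000 nM. Compound 3, `CCNc1ccc2c(c1)OC(N)=C(C#N)C2c1cccc(OC)c1`, gives 110000000 nM. Compound 2, `COc1ccc2c(c1)OC(N)=C(C#N)C2c1cccc(Cl)c1`, gives 80000000 nM. On these numbers compound 3 stands level with compound 1, and the value of compound 2 differs from that of compound 3 only within the usual scatter of repeated measurements, so none of the three stands apart.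

Compound 4, `CCNc1ccc2c(c1)OC(N)=C(C#N)C2c1cccc(Cl)c1`, has not yet been measured. It differs from compound 3 in one place: chloro in place of methoxy on an aromatic carbon. Going by the values given here, the only measured single change on that same aromatic carbon is no change at the digits printed from compound 1 to compound 3 (within the scatter), where one group replaced another and the number did not move. Among the compounds with values here, compound 2 also carries chloro on that carbon, but it differs from compound 3 in a second place as well, so its value shows only that such a compound lands in the same region. No movement beyond the scatter is therefore expected in this assay, and the step of a 1.1-fold lower number from compound 3 to compound 4 (0.04 log units; within the scatter) is estimated to be flat. Compound 4 is expected to give about 100000000 nM, between 50000000 nM and 220000000 nM.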

Compound 4, half-maximal effective concentration: 120000000 nM
Beside the measured number, compound 4's estimate is 1.2-fold (0.08 log units) below it; low and high end bracket the measured number.
By their numbers in this assay, from the lowest: compounds 2, 1, 3 and 4 (each within the scatter of the next).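

In this assay the aromatic carbon that held nitro or methoxy also takes chloro without any movement beyond the scatter (a 1.1-fold higher number from compound 3 to compound 4 (0.04 log units; within the scatter)) and (a 1.1-fold higher number from compound 1 to compound 4 (0.04 log units; within the scatter)). Nitro, methoxy and chloro therefore give values within the scatter of one another on this carbon, where the earlier compounds offered only a single such swap. With chloro held fixed, a single change at the second varying place on the shared core, from methoxy to ethylamino, can now be read as well, and this also stays within the scatter (a 1.5-fold higher number from compound 2 to compound 4 (0.18 log units; within the scatter)).

As far as these compounds go, whether an amine or a carboxylic acid on the first carbon, or a longer chain in place of ethylamino, would shift the number remains open. No measured evidence bears on why these values stay together.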